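This account rests on a few compounds, and the source may have more. Where it says the series, first, only, none or still open, it means among the compounds named here.

Compound 1 `CCCCCCCCCCCCCCc1ccc(NC(=O)Nc2c(C(C)C)cccc2C(C)C)cc1`: 500 nM
Compound 2 `CC(C)c1cccc(C(C)C)c1NC(=O)Nc1ccccc1`: 910 nM
Compound 3 `CCCCCCCCCCCCc1ccc(NC(=O)Nc2c(C(C)C)cccc2C(C)C)cc1`: 15 nM

Among the measured compounds shown here, in an assay on isolated protein for inhibition of acyl-CoA:cholesterol acyltransferase (Oryctolagus cuniculus) (on this read-out lower numbers stand for stronger inhibition and higher numbers for weaker inhibition), compound 3 has the lowest number of the three compounds measured so far. Its nearest neighbour is reached through the step of a 33-fold lower number from compound 1 to compound 3 (1.52 log units; beyond the scatter), and compound 2 lies further away still with 910 nM. Compound 4 `CCCCCCCCCCc1ccc(NC(=O)Nc2c(C(C)C)cccc2C(C)C)cc1` differs from compound 3 by hydrogen in place of ethyl on a saturated chain carbon, ten or more bonds along the chain from an aromatic carbon. For the measured compounds named here, only one measured step bears on this change, namely a 33-fold lower number from compound 1 to compound 3 (1.52 log units; beyond the scatter), which was large and pointed toward a lower number. Whether a second shortening of the chain continues in that direction cannot be told from three compounds, so in this assay a step expected here is smaller and uncertain in direction. Compound 4 is therefore expected near 20 nM, within a range from 5 nM to 80 nM. The expected step is a 1.3-fold higher number from compound 3 to compound 4 (0.12 log units; within the scatter).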

Compound 4, half-maximal inhibitory concentration: 13 nM
Beside the measured number, compound 4's estimate is 1.5-fold (0.19 log units) above it; the measured number falls inside the stated range.
By their numbers in this assay, from the lowest: compounds 4 and 3 (each within the scatter of the next); then compounds 1 and 2 (each within the scatter of the next).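

In this assay, the same swap of ethyl for hydrogen on the shorter chain gives a 1.2-fold lower number from compound 3 to compound 4 (0.06 log units; within the scatter), so the large step seen earlier does not repeat here. Hydrogen in place of butyl gives a 38-fold lower number from compound 1 to compound 4 (1.59 log units; beyond the scatter), and decyl in place of hydrogen on an aromatic carbon gives a 70-fold lower number from compound 2 to compound 4 (1.85 log units; beyond the scatter), which shows that compound 4 keeps the large distance from both compound 1 and compound 2. Nothing measured here explains these steps. Still open, as far as these compounds go, is whether a hexyl chain would stay within the scatter of compound 4, and what an amine or a carboxylic acid on the chain would do.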